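This account rests on a few compounds, and the source may have more. Where it says the series, first, only, none or still open, it means among the compounds named here.

Compound 1 `CC(=O)N[C@@H]1CCC[C@H](C(=O)Nc2cc(-c3cnn4c3CC(C)(C)CC4)ccn2)C1` and compound 2 `CC(=O)N[C@@H]1CCC[C@H](C(=O)Nc2cc(-c3cnn4c3CC(C)(C)C4)ccn2)C1` share the same core and differ in the size of the saturated ring fused to the pyrazole. In an ADME assay on cells (Hepatocyte, Homo sapiens) for metabolic stability, using equilibrium dialysis (on this read-out lower numbers stand for slow clearance and higher numbers for fast clearance), compound 1 gives 4.3 uL/min. In this assay compound 2 returns only < 1 uL/min, which is a limit of the measurement and not a number. Among the measured compounds shown here, the pair therefore shows only that compound 2 sits at or beneath the floor of the assay, consistent with the limit of < 1 uL/min in this assay, at which 1 of the 2 values shown sits, so how far apart the two really lie cannot be read from these figures.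

Compound 3 `CC(=O)N[C@@H]1CCC[C@H](C(=O)Nc2cc(-c3cnn4c3CC(C)(C)C4)c(F)cn2)C1` is built from compound 2 by a single change: fluoro in place of hydrogen on an aromatic carbon. No measured step of this kind is available among the compounds shown, so no size for it can be taken from the data. Because compound 2 already reports < 1 uL/min, the expected step of an at least 1.2-fold higher number from compound 2 to compound 3 (0.07 log units; that floor lies within the scatter) is no more than the ordinary scatter, in no particular direction. Compound 3 is estimated to give 1.2 uL/min in this assay, within a range of 0.4 uL/min to 3.5 uL/min, with a substantial chance that the assay again returns only a limit.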

Compound 3, intrinsic clearance in a liver preparation (reported as CLH), per the amount of preparation that the assay uses in the Hepatocyte assay: 2.6 uL/min
Compound 3: middle estimate off by 2.2-fold (0.34 log units), on the low side, within the range that was stated.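

Compound 2 and compound 3 differ only by fluoro in place of hydrogen on an aromatic carbon, ortho to a large group and two atoms from the ring nitrogen, and in the Hepatocyte assay this pair gives an at least 2.6-fold higher number from compound 2 to compound 3 (0.41 log units; beyond the scatter), the first sign that the read-out responds to a change at this position. The size of that step is only a minimum, because compound 2 stands at a limit of the measurement and not at a number: the limit of < 1 uL/min in the Hepatocyte assay, at which 1 of the 3 values shown sits. In a physicochemical assay for solubility, in phosphate buffer, at pH 7.4 (on this read-out lower numbers stand for lower solubility and higher numbers for higher solubility), compound 2 gives 970000 nM and compound 3 gives 550000 nM, which is a 1.8-fold lower number from compound 2 to compound 3 (0.25 log units; within the scatter), so the two compounds cannot be told apart on this read-out.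

Going by these compounds, with a single substitution, it stays open whether chloro, methoxy or a nitrile on the same aromatic carbon would move the clearance read-out as fluoro does. On these data alone, it also stays open how large the true step is, and whether fluoro at this carbon would act in the same way on compound 1, with its larger saturated ring fused to the pyrazole.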